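Ring-nitrogen substituent swap: carbonyl to sulfonyl

This account rests on a few compounds, and the source may have more. Where it says the series, first, only, none or still open, it means among the compounds named here.

Compound 2 `Cc1ccc(C(=O)N2N=C(c3ccc(N4CCN(C)CC4)cc3)CC2c2ccc(N(C)C)cc2)cc1` gives -2.5% in a functional assay on HCC1806 cells (Homo sapiens) for inhibition, read by sulforhodamine B assay, tested at 10 uM (a lower number here means less inhibition, a higher number more inhibition at the concentration tested (going by the name of the read-out)), and stands second highest of the three numbers measured. Its nearest neighbour is compound 1 `COC(=O)CC(=O)N1N=C(c2ccc(N3CCN(C)CC3)cc2)CC1c1ccc(N(C)C)cc1` with -8.3%, the gap being a number 5.8 percentage points higher from compound 1 to compound 2 (within the scatter). Compound 3 `CN1CCN(c2ccc(C3=NN(C(=O)/C=C/c4ccccc4)C(c4ccc(N(C)C)cc4)C3)cc2)CC1` gives 71%, so that a number 73.5 percentage points higher from compound 2 to compound 3 (beyond the scatter) is large. Compound 4 `CN1CCN(c2ccc(C3=NN(S(=O)(=O)c4ccc(F)cc4)C(c4ccc(N(C)C)cc4)C3)cc2)CC1` differs from compound 2 by (4-fluorophenyl)sulfonyl in place of (4-methylphenyl)carbonyl on an amine nitrogen in a ring. Among the measured compounds shown here, the two measured steps on the same carbonyl carbon show that 4-methylphenyl and (methoxycarbonyl)methyl give about the same low number, while only 2-phenylethenyl brings a large rise; no measured step covers a sulfonyl on this nitrogen. The change to compound 4 is therefore expected to give a number 7.5 percentage points higher from compound 2 to compound 4 (within the scatter), not beyond the scatter. For compound 4 the estimate is 5%, with a range from -15% to 35%.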

Compound 4, a percentage reported as inhibition, at one concentration (the size of the read-out at that concentration, not a potency): 92.3%
Compound 4: middle estimate off by 87.3 percentage points, on the low side; the measured number lies above the stated range.
By their numbers in this assay, from the lowest: compounds 1 and 2 (each within the scatter of the next); then compound 3; then compound 4.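

On this amine nitrogen in a ring, a sulfonyl group carries a high number: (4-fluorophenyl)sulfonyl gives a number 94.8 percentage points higher from compound 2 to compound 4 (beyond the scatter) and a number 100.6 percentage points higher from compound 1 to compound 4 (beyond the scatter). Among the compounds shown here, the step of a number 21.3 percentage points higher from compound 3 to compound 4 (beyond the scatter) shows that (2-phenylethenyl)carbonyl is not the only group here that lifts the number far above that of the two low carbonyl compounds. Nothing available bears on why this exchange has so large an effect. The exchange alters both the sulfonyl link and the ring substituent, so their shares cannot be separated. A (4-methylphenyl)sulfonyl group on the same nitrogen would divide them, while a methylsulfonyl group would test the need for the aromatic ring.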